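The source may hold more compounds than are shown below. What is called first, only, known or untested is meant among the compounds shown, and "the series" means these compounds.

In a functional assay on HT-29 cells (Homo sapiens) for inhibition, read by MTT assay, with a stated time of 48 h (on this read-out lower numbers stand for stronger inhibition and higher numbers for weaker inhibition), three compounds sharing one core have been measured so far. Compound 1 `CCSc1nnc(-c2cc(OC)c(OC)c(OC)c2)n1-c1ccc(OC)cc1` gives > 60000 nM, which is a limit and not a number. Compound 2 `COc1ccc(-n2c(SCC(=O)c3ccccc3)nnc2-c2cc(OC)c(OC)c(OC)c2)cc1` gives > 60000 nM, again a limit. For the measured compounds named here, compound 3 `COc1cc(-c2nnc(SCC(=O)c3ccccc3)n2-c2ccc(N(C)C)cc2)cc(OC)c1OC` gives 45200 nM, the only true number among the three.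

Compound 4 `COc1cc(-c2nnc(SCC(=O)Nc3ccc(Cl)cc3)n2-c2ccc(N(C)C)cc2)cc(OC)c1OC` differs from compound 3 in one group: (4-chlorophenyl)amino in place of phenyl on a carbonyl carbon. Put simply, (4-chlorophenyl)amino stands in place of phenyl on a carbonyl carbon, which adds a hydrogen-bond donor.

Going by the values given here, two measured steps bear on this only loosely. One is a step that the two limits leave unreadable from compound 1 to compound 2, which brought in the benzoyl group altered here. The other is an at least 1.3-fold lower number from compound 2 to compound 3 (0.12 log units; that floor lies within the scatter), made at a different group. Neither gives a usable size for the new change.

Compound 3, at 45200 nM, has little room to rise before this assay stops giving numbers, so any readable change is expected to be downward. The expected change is a 2.3-fold lower number from compound 3 to compound 4 (0.35 log units; beyond the scatter), a modest and very uncertain move. The estimate for compound 4 is 20000 nM, with an expected range of 3000 nM to 60000 nM.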

Compound 4, half-maximal inhibitory concentration: > 60000 nM
Compound 4 gave a limit, no number; the forecaster's own chance of this, stated with the estimate: 25%; at least 3.0-fold (0.47 log units) between middle value and limit.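

In this assay, putting (4-chlorophenyl)amino in place of phenyl on a carbonyl carbon gives an at least 1.3-fold higher number from compound 3 to compound 4 (0.12 log units; that floor lies within the scatter). For the compounds shown here, this is the first change at this position with the dimethylamino group present, and although it adds a hydrogen-bond donor, it brings no lower number; compound 4 reads only as a limit, so the true size of the step cannot be told. Compound 3 thus remains the only compound with a true number, which leaves little to compare: the limit of > 60000 nM in this assay, at which 3 of the 4 values shown sit.

Going by these compounds, it remains open whether the chlorine, the amide hydrogen or neither accounts for this result, a question that a plain phenylamino group on the same carbonyl carbon could help to settle. On these data alone, it is also open whether a smaller methylamino group there would give a readable number.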